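Ester to ethylamide on the shared core

A few compounds are considered here, and "the series" means these few. Any claim that something is new, unique, unknown or untested is made for them only; others in the source may bear on it.

In a functional assay (aorta) with Rattus norvegicus as the target (a higher number here means a weaker inhibitor, a lower number a stronger inhibitor), compound 1 `CCOC(=O)CN(c1ccccc1)[C@H]1c2cc(C#N)ccc2OC(C)(C)[C@@H]1O` gives > 30000 nM, a limit rather than a number. In this assay compound 2 `CCOC(=O)CN(c1nc2ccccc2o1)[C@H]1c2cc(C#N)ccc2OC(C)(C)[C@@H]1O` gives > 30000 nM, again a limit. The step that the two limits leave unreadable from compound 1 to compound 2 cannot be read, since the limit of > 30000 nM in this assay, at which 2 of the 2 values shown sit, holds both values. Compound 3 `CCNC(=O)CN(c1ccccc1)[C@H]1c2cc(C#N)ccc2OC(C)(C)[C@@H]1O` differs from compound 1 by ethylamino in place of ethoxy on a carbonyl carbon. Among the compounds with values here, no measured step bears on this change, and compound 1 has no readable neighbour. Compound 3 is expected to stay near the limit, so the step that the limit leaves unreadable from compound 1 to compound 3 is an estimate without measured support. Compound 3 is expected at 40000 nM, within 8000 nM to 200000 nM.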

Compound 3, half-maximal inhibitory concentration: > 30000 nM
Compound 3 gave a limit, no number; the forecaster's own chance of this, stated with the estimate: 80%; the middle value does not contradict the limit.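

Compound 3, like compound 1, gives only a limit, so the step from ethoxy to ethylamino cannot be read: the limit of > 30000 nM in this assay, at which 3 of the 3 values shown sit.

The compounds shown leave open which change on the shared core, if any, would bring a readable value in this assay.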